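Swapping benzamido for acetamidomethyl on a kinase inhibitor

This account rests on a few compounds, and the source may have more. Where it says the series, first, only, none or still open, it means among the compounds named here.

Compound 1 `Nc1ncccc1-c1nc2cccnc2n1-c1ccc(NC(=O)c2ccccc2)cc1` is the reference point of this series. In an in vitro assay on Sf9 cells for inhibition of RAC-alpha serine/threonine-protein kinase (Homo sapiens), read by AlphaScreen, with a stated time of 20 min (on this read-out higher numbers stand for weaker inhibition and lower numbers for stronger inhibition), compound 1 gives 14 nM, the lowest number among the values shown. Compound 2 `COc1ccccc1Cn1c(-c2cccnc2N)nc2cccnc21` gives 58000 nM in this assay, a far higher number and well beyond the scatter. Compound 3 `COc1ccccc1Cn1c(-c2cccnc2N)nc2cc(Br)cnc21` sits at the limit of > 300000 nM in this assay, at which 1 of the 3 values shown sits, reported as > 300000 nM. Within the data shown here, the single step between measured compounds that differ in one place is an at least 5.1-fold higher number from compound 2 to compound 3 (0.71 log units; beyond the scatter), bromo in place of hydrogen on an aromatic carbon of the shared core.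

Compound 4 `CC(=O)NCc1ccc(-n2c(-c3cccnc3N)nc3cccnc32)cc1` differs from compound 1 by acetamidomethyl in place of benzamido on an aromatic carbon. Among the measured compounds shown here, none of the measured steps touches this position or either of these groups, and the one measured step concerns a different change on a different part of the molecule, so it offers no direct guide. For the measured compounds named here, with no measured precedent for removing the aromatic ring of the benzamido group and putting acetamidomethyl in its place, a moderate loss against compound 1 is the cautious expectation, with wide uncertainty. For compound 4 a step of a 7.1-fold higher number from compound 1 to compound 4 (0.85 log units; beyond the scatter) is therefore expected. Compound 4 is estimated at 100 nM, with a range from 15 nM to 800 nM.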

Compound 4, half-maximal inhibitory concentration: 810 nM
Estimate against measurement, compound 4: 8.1-fold (0.91 log units) below; the whole stated range lies below it.
By their numbers in this assay, from the lowest: compound 1; then compound 4; then compound 2. At a limit, above all of these: compound 3.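

Among these compounds, until compound 4, no measured step had touched the group on this six-membered aromatic ring of carbon only, para to a large group. In this assay the exchange of benzamido for acetamidomethyl gives a 58-fold higher number from compound 1 to compound 4 (1.76 log units; beyond the scatter) and so shows that this place is far from indifferent to which group it carries, even though both groups hold an amide and the counts of hydrogen-bond donors and acceptors printed for them are equal. Nothing measured here on any property of these groups bears on this step.

The compounds shown do not separate the loss of the aromatic ring from the change in how the amide is attached, since acetamidomethyl differs from benzamido in both respects, and a plain acetamido group or a benzamidomethyl group at this place would pull the two apart. Also open, from the compounds shown here alone, is how a simple amine, a carboxylic acid or a longer chain would fare at this place, and whether bromo on the shared core would act of compound 1 as it does from compound 2 to compound 3.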